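A few compounds are considered here, and "the series" means these few. Any claim that something is new, unique, unknown or untested is made for them only; others in the source may bear on it.

Compound 1: `CCCCCCCc1cccc(N2CCNCC2)n1` gives 10 mg/kg in a functional assay on the whole organism with Mus musculus as the target, in the maximal electroshock model, with a stated time of 120 min; a lower number here means that less compound is needed, a higher number that more compound is needed for the effect.
Compound 2: `CCCCc1cccc(N2CCNCC2)n1` gives 30 mg/kg in this assay.

Going by the values given here, on these two numbers compound 2 stands highest, that is, more of it is needed than of compound 1, which is the only other measured compound. Compound 3 is `c1cc(CC2CCCCC2)nc(N2CCNCC2)c1`, not yet measured. It differs from compound 2 by cyclohexyl in place of propyl on a saturated chain carbon bound to an aromatic carbon. Among the compounds with values here, the one measured step that bears on this is a 3.0-fold higher number from compound 1 to compound 2 (0.48 log units; beyond the scatter), where a shorter chain on the shared core went with a modestly higher number. The change to compound 3 goes the other way in size, adding heavy atoms where the chain sits, so a step of similar size in the opposite direction, toward a lower number, is expected: a 2.0-fold lower number from compound 2 to compound 3 (0.30 log units; within the scatter). For compound 3 the expected value in this assay is therefore 15 mg/kg, with a range from 5 mg/kg to 50 mg/kg.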

Compound 3, minimum effective dose: 100 mg/kg
Compound 3: the middle estimate sits 6.7-fold (0.82 log units) below what was measured, outside the stated range (above it).
By their numbers in this assay, from the lowest: compound 1; then compound 2; then compound 3.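

In this assay, a bigger carbon group at this place does not by itself mean that less compound is needed: cyclohexyl in place of propyl gives a 3.3-fold higher number from compound 2 to compound 3 (0.52 log units; beyond the scatter). The comparison with the open hexyl group is sharper, with a 10-fold higher number from compound 1 to compound 3 (1.00 log units; beyond the scatter), so among these compounds the longer open chain goes with a lower number, and compound 3, with its ring, goes against any simple rule of more carbon, lower number. Nothing available here explains why the ring behaves this way.

The compounds shown leave open whether a phenyl or cyclopentyl group at this place would follow cyclohexyl or the open chains. They also leave open whether a chain longer than that of compound 1, or one ending in an amine, would lower the number further.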